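The source may hold more compounds than are shown below. What is called first, only, known or untested is meant among the compounds shown, and "the series" means these compounds.

Measured compounds:
compound 1, `CCc1nc2cc3c(cc2o1)C1CNCC3C1`, 12 nM
compound 2, `c1ccc(Cc2nc3cc4c(cc3o2)C2CNCC4C2)cc1`, 100 nM

Compound 2 gives the highest of the two numbers in an assay for binding affinity to Neuronal acetylcholine receptor; alpha4/beta2 (Rattus norvegicus); a lower number here means a stronger inhibitor, a higher number a weaker inhibitor; its nearest neighbour is compound 1, at an 8.3-fold higher number from compound 1 to compound 2 (0.92 log units; beyond the scatter). Compound 3, `CC(C)c1nc2cc3c(cc2o1)C1CNCC3C1`, is not yet measured in this assay. It differs from compound 2 by isopropyl in place of benzyl on an aromatic carbon. Among the measured compounds shown here, the only measured step that bears on this change is the one from compound 1 to compound 2, where an 8.3-fold higher number from compound 1 to compound 2 (0.92 log units; beyond the scatter) followed from the phenyl in place of methyl on the chain carbon. Compound 3 carries a group of three carbon atoms without a ring, closer in size to the ethyl of compound 1 than to the benzyl of compound 2, so a step back toward the number of compound 1 is expected for compound 3, namely a 4.0-fold lower number from compound 2 to compound 3 (0.60 log units; beyond the scatter). Compound 3 is therefore estimated at 25 nM, with a range from 8 nM to 80 nM.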

Compound 3, inhibition constant: 7.6 nM
Compound 3: the middle estimate sits 3.3-fold (0.52 log units) above what was measured; measured number outside the range, below it.
By their numbers in this assay, from the lowest: compounds 3 and 1 (each within the scatter of the next); then compound 2.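

In this assay, isopropyl in place of benzyl on the aromatic carbon gives a 13-fold lower number from compound 2 to compound 3 (1.12 log units; beyond the scatter), a step larger than the one that separated the first two compounds, so the benzyl compound stands apart from both compounds without a ring at this position. The extra methyl on the chain gives a 1.6-fold lower number from compound 1 to compound 3 (0.20 log units; within the scatter), which means that ethyl and isopropyl stand level here and the position accepts this branching. Nothing in the data shown accounts for the gap between benzyl and the two smaller groups.

From the compounds shown here alone, it remains open whether the phenyl ring of benzyl or simply its seven heavy atoms set compound 2 apart, which a cyclohexylmethyl group could address. Going by these compounds, how a tert-butyl group, a longer chain such as n-butyl, or a chain ending in an amine would read at this position also stays open.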